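Hydrazide in place of benzylamide: an untested single exchange

A few compounds are considered here, and "the series" means these few. Any claim that something is new, unique, unknown or untested is made for them only; others in the source may bear on it.

Measured so far:
Compound 1 `CC(C)(C)OC(=O)N1CCc2c(sc(N)c2C(=O)O)C1` gives 12100 nM in an in vitro assay on CHOk1 cells with adenosine receptor A1 (Homo sapiens) as the target; a higher number here means that more compound is needed for the effect, a lower number that less compound is needed.
Compound 2 `Nc1sc2c(c1C(=O)NCc1ccccc1)CCN(Cc1ccccc1)C2` gives 13100 nM in this assay.
Compound 3 `Nc1sc2c(c1C(=O)NCc1cccc(C(F)(F)F)c1)CCN(Cc1ccccc1)C2` gives 15500 nM in this assay.

All three numbers sit within the scatter of one another, so compound 2 cannot be placed above or below compounds 1 and 3 on these data. Compound 4 `NNC(=O)c1c(N)sc2c1CCN(Cc1ccccc1)C2` differs from compound 2 in one place: amino in place of benzyl on an amide-type nitrogen. Within the data shown here, the only measured single step, a 1.2-fold higher number from compound 2 to compound 3 (0.07 log units; within the scatter), concerns a different position and offers no direct guide. No change at the amide-type nitrogen has been measured. The author therefore expects no step beyond the scatter, with a 1.0-fold lower number from compound 2 to compound 4 (0.00 log units; within the scatter) as the estimated step. Compound 4 is thus expected to give 13000 nM, within a range of 5000 nM to 35000 nM.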

Compound 4, half-maximal effective concentration: 8900 nM
Compound 4: the middle estimate sits 1.5-fold (0.16 log units) above what was measured; measured number inside the range.
By their numbers in this assay, from the lowest: compounds 4, 1, 2 and 3 (each within the scatter of the next).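

At the amide-type nitrogen, amino in place of benzyl gives a 1.5-fold lower number from compound 2 to compound 4 (0.17 log units; within the scatter) in this assay, the first view of this position. Compounds 2 and 4 cannot be told apart, even though this exchange takes away a benzyl group with its aromatic ring and leaves a single nitrogen there. No available evidence explains this result. On these data alone, whether a methyl, a phenethyl or a longer chain ending in a carboxylic acid on this nitrogen would give a step beyond the scatter remains open.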